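Methylsulfamoyl in place of hydroxymethyl: an expected step

This account rests on a few compounds, and the source may have more. Where it says the series, first, only, none or still open, it means among the compounds named here.

Measured so far in an assay for binding affinity to 17-beta-hydroxysteroid dehydrogenase type 2 (Homo sapiens), with a stated time of 20 min, tested at 1 uM; a lower number here means less inhibition, a higher number more inhibition at the concentration tested (going by the name of the read-out):
- compound 1, `OCc1ccc(-c2ccc3c(O)cccc3c2)cc1`: 31%
- compound 2, `COc1ccncc1-c1ccc2c(O)cccc2c1`: < 10%, which is a limit of the assay rather than a number

Compound 1 therefore holds the only number shown in this assay; the other value is a limit, as the limit of < 10% in this assay, at which 1 of the 2 values shown sits, states, with compound 2 sitting at it.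

Compound 3, `CNS(=O)(=O)c1ccc(-c2ccc3c(O)cccc3c2)cc1`, has not been measured. It differs from compound 1 in one place: methylsulfamoyl in place of hydroxymethyl on an aromatic carbon. No step between two measured compounds is shown that would tell how such a change behaves, so the expectation for compound 3 rests on compound 1 alone. The step from compound 1 to compound 3 in this assay is expected to be a number 3 percentage points lower from compound 1 to compound 3 (within the scatter), that is, no shift beyond the usual scatter in either direction. Compound 3 is thus estimated to give 28%, within a range from 8% to 50%.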

Compound 3, a percentage reported as inhibition, at one concentration (the size of the read-out at that concentration, not a potency): 57%
Compound 3: the middle estimate sits 29 percentage points below what was measured; the whole stated range lies below it.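

In this assay, replacing hydroxymethyl with methylsulfamoyl gives a number 26 percentage points higher from compound 1 to compound 3 (beyond the scatter) on the aromatic carbon para to a large group. This is the first step shown between two measured compounds that differ in one place, and it shows that the read-out at this position responds to the group placed there and that the larger methylsulfamoyl is accepted with a gain in inhibition at the tested concentration. Nothing measured here explains why the step goes this way.

One step cannot separate the contribution of the sulfonyl part from that of the methyl on the nitrogen. As far as these compounds go, whether an unsubstituted sulfamoyl, a carboxylic acid or a longer chain at this position would go the same way remains open.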